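A few compounds are considered here, and "the series" means these few. Any claim that something is new, unique, unknown or untested is made for them only; others in the source may bear on it.

Series notes. Two members of the series carry a measurement in a functional assay on the whole organism for inhibition, with Mus musculus as the target, at a dose of 80 mg/kg by the oral route; a lower number here means a weaker effect, a higher number a stronger effect of the compound at the dose given. Compound 1, `CCCCN1C(=O)NC2(CC2(C)C)C1=O`, carries a butyl chain on the shared core; in this assay compound 1 gives 60%. Compound 2, `CC1(C)CC12NC(=O)N(c1ccccc1)C2=O`, bears a phenyl group on the same core; in this assay compound 2 gives 60%. Compound 2 thus stands level with compound 1 at the digits shown, and the two values lie within the usual scatter of each other, so no order between them can be read. Among the measured compounds shown here, no pair among the measured compounds differs in a single place, so no measured step is available to set the size of the next one.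

Compound 3, `CC1(C)CC12NC(=O)N(c1ccc(F)cc1)C2=O`, is the next member. It differs from compound 2 in one place: fluoro in place of hydrogen on an aromatic carbon. For the measured compounds named here, the only comparison in hand is flat, with compound 2 giving 60%. For this change the step in this assay is expected to be small, no change at the digits printed from compound 2 to compound 3 (within the scatter), with no direction beyond the scatter. Compound 3 is therefore estimated at 60%, with a range from 45% to 75%.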

Compound 3, a percentage reported as inhibition, in the whole organism at one dose (the size of the read-out at that dose, not a potency): 70%
Compound 3: middle estimate off by 10 percentage points, on the low side; low and high end bracket the measured number.
By their numbers in this assay, from the lowest: compounds 1, 2 and 3 (each within the scatter of the next).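

In this assay, among the compounds shown here, fluoro in place of hydrogen on an aromatic carbon, para to a large group, gives a number 10 percentage points higher from compound 2 to compound 3 (within the scatter), the first measured step between compounds that differ in one place. This position on the six-membered aromatic ring therefore accepts fluoro with no change beyond the usual scatter, although this single step sets no direction for the change. No measurement available here offers an explanation for the size of this step.

From the compounds shown here alone, it remains open whether a chloro group, a methoxy group or an amine at the same position would move the read-out beyond the scatter, or whether fluoro on another carbon of the ring would leave it just as little changed. Because the read-out comes from one oral dose and is not a potency, it also leaves open how compound 2 and compound 3 would compare at other doses.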